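The source may report more compounds than this note shows. Statements on the series, on what has been measured and on what is new or still open speak of the compounds shown alone.

Of the compounds shown here, three built on one shared core have been measured in a functional assay on the whole organism (strain Wistar) for inhibition, with Rattus norvegicus as the target, read by paw edema, with stated times of 60 min and 1 h, at a dose of 100 mg/kg by the oral route; on this read-out lower numbers stand for less inhibition and higher numbers for more inhibition at the one dose given (going by the name of the read-out). Compound 1 `COc1cc2c(cc1OC)C(CC(=O)O)CC2` gives 18.8%, compound 2 `CNC(=O)CC1CCc2cc(OC)c(OC)cc21` gives 15.6%, and compound 3 `COc1cc2c(cc1OC)C(CC(=O)NC1CCCC1)CC2` gives 40.6%. Compound 3 thus holds the highest of the three numbers: the gap from compound 1 is a number 21.8 percentage points higher from compound 1 to compound 3 (beyond the scatter), the gap from compound 2 is a number 25 percentage points higher from compound 2 to compound 3 (beyond the scatter), while the two lower compounds are separated only by a number 3.2 percentage points lower from compound 1 to compound 2 (within the scatter). Compound 4 `COc1cc2c(cc1OC)C(CC(=O)N1CCCCC1)CC2` is the untested member, and it differs from compound 3 in one place: piperidin-1-yl in place of cyclopentylamino on a carbonyl carbon. For the measured compounds named here, the two steps ending at compound 3 bear on this change, since both concern what is attached at the carbonyl carbon or on the amide-type nitrogen, and both were modest gains; no measured step shows what happens when the hydrogen-bond donor is removed while a ring of the same size in atoms is kept. A small downward step is expected, a number 8.6 percentage points lower from compound 3 to compound 4 (within the scatter). In this assay compound 4 is expected to give about 32%, within a range from 14% to 50%.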

Compound 4, a percentage reported as inhibition, in the whole organism at one dose (the size of the read-out at that dose, not a potency): 18.8%
Compound 4: the middle estimate sits 13.2 percentage points above what was measured; the range from low to high includes it.
By their numbers in this assay, from the lowest: compounds 2, 1 and 4 (each within the scatter of the next); then compound 3.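

In this assay, the result shows that the higher number at this carbonyl carbon does not follow from the heavy-atom count alone: piperidin-1-yl matches cyclopentylamino in that count, yet the change gives a number 21.8 percentage points lower from compound 3 to compound 4 (beyond the scatter). Compound 4 also sits level with the two lower compounds, with a number 3.2 percentage points higher from compound 2 to compound 4 (within the scatter) and no change at the digits printed from compound 1 to compound 4 (within the scatter), so among these four compounds only cyclopentylamino stands apart. The change removes the hydrogen-bond donor and alters the ring at once, and nothing available here explains the drop.

The compounds shown leave open whether the donor or the carbon-only ring accounts for the number of compound 3. A methyl(cyclopentyl)amino group and a cyclohexylamino group on the same carbonyl carbon would bear on that question.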